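Replacing Dichlorophenyl by Phenylethenyl on the Imine Carbon

This account rests on a few compounds, and the source may have more. Where it says the series, first, only, none or still open, it means among the compounds named here.

Compound 1 `Clc1ccccc1/C=N/c1sc2c(c1-c1nc3ccccc3s1)CCC2`: 180 ug/mL
Compound 2 `Clc1ccc(/C=N/c2sc3c(c2-c2nc4ccccc4s2)CCC3)c(Cl)c1`: 310 ug/mL

Among the compounds with values here, both compounds have been tested in an ADME assay on HepG2 cells (Homo sapiens) for cytotoxicity, read by MTT assay, with a stated time of 72 h; on this read-out higher numbers stand for lower toxicity in this test and lower numbers for higher toxicity in this test. Compound 2 gives 310 ug/mL and compound 1 gives 180 ug/mL; of the two numbers, that of compound 2 is the one standing further from toxicity on this read-out, but the step of a 1.7-fold higher number from compound 1 to compound 2 (0.24 log units; within the scatter) lies within the scatter, so the two compounds cannot be told apart by this assay.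

Compound 3 `C(=C/c1ccccc1)\C=N\c1sc2c(c1-c1nc3ccccc3s1)CCC2` differs from compound 2 by 2-phenylethenyl in place of 2,4-dichlorophenyl on a carbon with a double bond to nitrogen. Within the data shown here, no measured step bears on this change: the one step recorded, a 1.7-fold higher number from compound 1 to compound 2 (0.24 log units; within the scatter), concerns only a chloro in place of hydrogen on an aromatic carbon and was itself within the scatter, so the two compounds measured so far give no hint that this part of the molecule moves the number. Compound 3 is therefore expected to show a step of a 1.2-fold lower number from compound 2 to compound 3 (0.09 log units; within the scatter), that is, none beyond the scatter. The estimate for compound 3 in this assay is 250 ug/mL, with a range from 100 ug/mL to 500 ug/mL.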

Compound 3, half-maximal cytotoxic concentration: 215 ug/mL
Estimate against measurement, compound 3: 1.2-fold (0.07 log units) above; the range from low to high includes it.
By their numbers in this assay, from the lowest: compounds 1, 3 and 2 (each within the scatter of the next).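

In this assay, 2-phenylethenyl in place of 2,4-dichlorophenyl on a carbon with a double bond to nitrogen gives a 1.4-fold lower number from compound 2 to compound 3 (0.16 log units; within the scatter), and 2-phenylethenyl in place of 2-chlorophenyl on the same carbon gives a 1.2-fold higher number from compound 1 to compound 3 (0.08 log units; within the scatter). The earlier pair differed only by a chloro in place of hydrogen, whereas this change removes all chlorine from the group and brings in a double bond outside aromatic rings, yet compound 3 still cannot be told apart from compound 1 or compound 2 in this test. The data offer no explanation for this lack of separation.

The groups compared at this carbon all contain a six-membered aromatic ring of carbon only, and neither 2,4-dichlorophenyl nor 2-phenylethenyl has a hydrogen-bond donor or acceptor, so these compounds do not show whether any group here can produce a step beyond the scatter. From the compounds shown here alone, it remains open whether an amine or a carboxylic acid on that aromatic ring, or a longer chain in place of 2-phenylethenyl, would move the number beyond the scatter.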